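Side-chain swap on a low-activity purine series

A few compounds are considered here, and "the series" means these few. Any claim that something is new, unique, unknown or untested is made for them only; others in the source may bear on it.

Of the compounds shown here, three have been tested in a functional assay on the whole organism (Tail, strain ICR) with Mus musculus as the target, in the tail flick test, with a stated time of 150 min, at a dose of 25 umol/kg by the oral route; on this read-out higher numbers stand for a stronger effect at the one dose given and lower numbers for a weaker effect. Compound 2, `C[C@@H](O)[C@H](NC(=O)CN(c1ncnc2c1ncn2C1CCCCO1)C1CC1)C(=O)OCc1ccccc1`, gives 6.53% in this assay. Compound 1, `NCCCC[C@H](NC(=O)CN(c1nc(Cl)nc2[nH]cnc12)C1CC1)C(=O)OCc1ccccc1`, gives 9.88%, and compound 3, `NCCCC[C@H](NC(=O)CN(c1nc(Cl)nc2[nH]cnc12)C1CC1)C(=O)O`, gives 11.6%. All three numbers lie within the scatter of one another, so none of them can be set apart as stronger or weaker.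

For the measured compounds named here, the only single-place step available is a number 1.7 percentage points higher from compound 1 to compound 3 (within the scatter), a change on the ester end of the chain rather than on the side chain. It does not bear directly on the change at hand, but it shows that altering one end of this molecule left the read-out essentially where it was.

Compound 4, `CC(C)(C)OC(=O)NCCCC[C@H](NC(=O)CN(c1ncnc2c1ncn2C1CCCCO1)C1CC1)C(=O)OCc1ccccc1`, differs from compound 2 by 4-((tert-butoxycarbonyl)amino)butyl in place of 1-hydroxyethyl on a saturated chain carbon bound to an amide-type nitrogen and a carbonyl carbon. Going by the values given here, no measured pair shows this change, and compound 1 and compound 2, which differ in more than one place, give values that sit within the scatter of each other. On this basis the step of a number 1.5 percentage points higher from compound 2 to compound 4 (within the scatter) is expected to stay within the scatter. Compound 4 is therefore estimated at 8%, with a likely range from 0% to 20%.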

Compound 4, a percentage reported as activity, at one dose (the size of the read-out at that dose, not a potency): 17.2%
Estimate against measurement, compound 4: 9.2 percentage points below, within the range that was stated.
By their numbers in this assay, from the lowest: compounds 2, 1, 3 and 4 (each within the scatter of the next, the first and the last beyond it).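

In this assay, for the compounds shown here, putting 4-((tert-butoxycarbonyl)amino)butyl in place of 1-hydroxyethyl gives a number 10.7 percentage points higher from compound 2 to compound 4 (beyond the scatter) and is the only single-place step in this set that goes beyond the scatter. This shows that the read-out responds to a change on this saturated chain carbon bound to an amide-type nitrogen and a carbonyl carbon, whereas the change at the ester end gave only a number 1.7 percentage points higher from compound 1 to compound 3 (within the scatter) on a different core. No measurement here accounts for the rise.

The new group differs from the old one in both its chain and its tert-butoxycarbonyl end, so the compounds shown cannot tell which of these parts matters. A plain butyl chain at this position, on the core of compound 4, would begin to separate the two.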